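Methylsulfonyl for methoxy on an amide-type nitrogen

The compounds below may be only part of what the source reports. "The series", "measured", "known", "first", "only" and "open" are said of these compounds alone.

Of the compounds shown here, two have so far been measured in a physicochemical assay for lipophilicity, read by LC-MS, using the shake flask method, with a stated time of 1 h, at pH 7.4; a lower number here means a more polar compound, a higher number a more lipophilic compound. Compound 1 (`CONC(=O)CCc1ccccc1`) gives 1.16, the higher of the two numbers. Compound 2 (`O=S(=O)(O)CCc1ccccc1`) gives -1.45, which leaves compound 1 above it by a gap well beyond the scatter of the method. The two do not differ in just one place, so no measured single change is available as a guide.

Compound 3 (`CS(=O)(=O)NC(=O)CCc1ccccc1`) has yet to be measured. It departs from compound 1 by one change, methylsulfonyl in place of methoxy on an amide-type nitrogen.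

Going by the values given here, with no measured step of this kind, the expectation rests on the two readings alone and is correspondingly uncertain. Compound 3 is expected to fall under compound 1 at 1.16 while staying over compound 2 at -1.45. In this assay a downward move beyond the scatter is therefore expected, and the estimated step is a number 1.46 log units lower from compound 1 to compound 3 (beyond the scatter). For compound 3 the estimated value is -0.3, with an expected range from -1 to 0.4.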

Compound 3, distribution coefficient: -1.02
Estimate against measurement, compound 3: 0.72 log units above; measured number below the stated range.
By their numbers in this assay, from the lowest: compound 2; then compound 3; then compound 1.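

In this assay, going by these compounds alone, methylsulfonyl in place of methoxy on an amide-type nitrogen gives the first single change with a measured outcome, and that outcome is large: a number 2.18 log units lower from compound 1 to compound 3 (beyond the scatter). It shows that the number at this position, on a nitrogen whose other neighbour is a carbonyl carbon, can shift strongly when only the group attached there changes, although this rests on one pair and on the shared core alone. Nothing measured here accounts for the size of the step.

From the compounds shown here alone, it remains open whether the step belongs to the methylsulfonyl group as a whole or would largely persist with a longer chain on the sulfur, as in ethylsulfonyl, or with trifluoromethylsulfonyl in its place. The compounds shown also leave open where other groups on this nitrogen, such as hydroxy, ethoxy or dimethylamino, would fall relative to methoxy and methylsulfonyl in this assay, and whether the same change would give a step of similar size on a different core.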